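Acyl variation on the amide of a shared core

A few compounds are considered here, and "the series" means these few. Any claim that something is new, unique, unknown or untested is made for them only; others in the source may bear on it.

Measured so far in an assay on LtK cells with ATP-sensitive inward rectifier potassium channel 11 (Homo sapiens) as the target; a lower number here means that less compound is needed, a higher number that more compound is needed for the effect: compound 1 `CC(C)=CC(=O)Nc1c(C(O)(C(F)(F)F)C(F)(F)F)ccc2ccccc12` gives 46 nM; compound 3 `O=C(Nc1c(C(O)(C(F)(F)F)C(F)(F)F)ccc2ccccc12)c1ccccc1` gives 44 nM; compound 2 `CCCC(C)C(=O)Nc1c(C(O)(C(F)(F)F)C(F)(F)F)ccc2ccccc12` gives only the assay limit > 10000 nM, so no number is known for it (the limit of > 10000 nM in this assay, at which 1 of the 3 values shown sits).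

Compound 4 `O=C(Nc1c(C(O)(C(F)(F)F)C(F)(F)F)ccc2ccccc12)c1cccc(Br)c1` differs from compound 2 by 3-bromophenyl in place of 1-methylbutyl on a carbonyl carbon. The closest measured step is an at least 220-fold lower number from compound 2 to compound 3 (2.35 log units; beyond the scatter), and an at least 210-fold higher number from compound 1 to compound 2 (2.33 log units; beyond the scatter) points the same way, both large. An aromatic ring on the carbonyl carbon thus sits near compound 3, and compound 4 is expected to fall far from the limit of compound 2, in this assay. The expected estimate for compound 4 is 50 nM, with a range of 15 nM to 200 nM. This implies an expected at least 200-fold lower number from compound 2 to compound 4 (2.30 log units; beyond the scatter).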

Compound 4, half-maximal effective concentration: 80 nM
Estimate against measurement, compound 4: 1.6-fold (0.20 log units) below; the range from low to high includes it.
By their numbers in this assay, from the lowest: compounds 3, 1 and 4 (each within the scatter of the next). At a limit, above all of these: compound 2.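

Bromo in place of hydrogen on an aromatic carbon gives no readable change in this assay (a 1.8-fold higher number from compound 3 to compound 4 (0.26 log units; within the scatter)), and 3-bromophenyl reads level with 2-methylprop-1-en-1-yl (a 1.7-fold higher number from compound 1 to compound 4 (0.24 log units; within the scatter)). A substituted aromatic ring on the carbonyl carbon thus also parts sharply from 1-methylbutyl (an at least 120-fold lower number from compound 2 to compound 4 (2.09 log units; beyond the scatter)). Compound 2 stands only at a limit of the assay: the limit of > 10000 nM in this assay, at which 1 of the 4 values shown sits.

Open, as far as these compounds go, is whether an amine or a carboxylic acid on the phenyl ring keeps the number level with compound 3. Also open, from the compounds shown here alone, is what separates 1-methylbutyl from 2-methylprop-1-en-1-yl, where a 2-methylpropyl chain would be the closest reading.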